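This account rests on a few compounds, and the source may have more. Where it says the series, first, only, none or still open, it means among the compounds named here.

Measured in an ADME assay on the whole organism (plasma) for pharmacokinetics, with Rhesus monkey (Macaca mulatta) as the target, read by LC-MS, at a dose of 1 mg/kg by the oral route; a higher number here means more compound in the circulation at the dose given, a lower number less compound in the circulation:
- compound 1 `COc1ccc2nc(COc3ccc(CC4(O)SC(=O)NC4=O)cc3)n(C)c2c1`: 7.33 ng.h/mL
- compound 2 `COc1ccc2nc(COc3ccc(CC(C(N)=O)[S+](C)[O-])cc3)n(C)c2c1`: 36.7 ng.h/mL
- compound 3 `COc1ccc2nc(COc3ccc(CC(SC(=O)N[C@@H]4O[C@H](C(=O)O)[C@@H](O)[C@H](O)[C@H]4O)C(=O)O)cc3)n(C)c2c1`: 673 ng.h/mL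

Compound 2 stands second of the three, above compound 1 and under compound 3, with both gaps beyond the scatter. The next step leads to compound 4 `COc1ccc2nc(COc3ccc(CC(SC)C(=O)O)cc3)n(C)c2c1`: a group of 6 heavy atoms (3 carbon, 2 oxygen, 1 sulfur; no ring) in place of a group of 7 heavy atoms (3 carbon, 1 nitrogen, 2 oxygen, 1 sulfur; no ring), on a saturated chain carbon bound to an aromatic carbon. Within the data shown here, the only measured step at this place is a 5.0-fold higher number from compound 1 to compound 2 (0.70 log units; beyond the scatter). It involves a different group, so it guides the size of the step only. Compound 3, which also holds a carboxy group, gives 673 ng.h/mL, and this single reading leans the expectation upward. A modest rise in this assay is therefore expected. The expected step is a 2.7-fold higher number from compound 2 to compound 4 (0.44 log units; beyond the scatter). The estimate for compound 4 is 100 ng.h/mL, with an expected range of 20 ng.h/mL to 500 ng.h/mL.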

Compound 4, area under the concentration-time curve: 76.8 ng.h/mL
Estimate against measurement, compound 4: 1.3-fold (0.11 log units) above; low and high end bracket the measured number.
By their numbers in this assay, from the lowest: compound 1; then compound 2; then compound 4; then compound 3.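

In this assay carboxy(methylsulfanyl)methyl on the saturated chain carbon bound to an aromatic carbon gives a 2.1-fold higher number from compound 2 to compound 4 (0.32 log units; beyond the scatter) and a 10-fold higher number from compound 1 to compound 4 (1.02 log units; beyond the scatter) with 5-hydroxy-2,4-dioxo-1,3-thiazolidin-5-yl as the group replaced. At this place, both ringless groups, in compound 2 and compound 4, read above the ring-bearing group of compound 1. Nothing at hand accounts for either step. Going by these compounds, whether the carboxy group or the methylsulfanyl group carries the gain stays open. An ethylsulfanyl group or a primary amine at this carbon would help separate the two.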